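The source may report more compounds than this note shows. Statements on the series, on what has been measured and on what is new or still open speak of the compounds shown alone.

In a functional assay on B16 cells (Mus musculus) for antiproliferative activity, with a stated time of 72 h (a lower number here means a stronger inhibitor, a higher number a weaker inhibitor), compound 1 `OC[C@H]1O[C@@H](n2cnc3c(NCc4ccc(Cl)cc4)ncnc32)[C@H](O)[C@@H]1O` gives > 166000 nM, which is a limit and not a number. Compound 2 `OC[C@H]1O[C@@H](n2cnc3c(NCc4ccc(Cl)c(Cl)c4)ncnc32)[C@H](O)[C@@H]1O` gives > 166000 nM, again a limit, so the step that the two limits leave unreadable from compound 1 to compound 2 has no readable size. Compound 3 `OC[C@H]1O[C@@H](n2cnc3c(NCc4cccc(O)c4O)ncnc32)[C@H](O)[C@@H]1O` has no number at all, and its result stands as "not determined" (no result reported). Compound 4 `Cc1cccc(CNc2ncnc3c2ncn3[C@@H]2O[C@H](CO)[C@@H](O)[C@H]2O)c1O` differs from it by methyl in place of hydroxy on an aromatic carbon, which is methyl in place of hydroxy on an aromatic carbon, turning 2,3-dihydroxybenzyl into 2-hydroxy-3-methylbenzyl. Among the measured compounds shown here, the only measured step is a different change and gives no size to carry over, so no direction can be stated. The expectation rests on (the limit of > 166000 nM in this assay, at which 2 of the 3 values shown sit). Compound 4 is expected near 170000 nM, with an estimated range of 40000 nM to 400000 nM.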

Compound 4, half-maximal inhibitory concentration: > 166000 nM
Compound 4 was reported as a limit; the forecaster's own chance of this, stated with the estimate: 65%; the middle value is on the limit's open side.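

In this assay, among the compounds shown here, compound 4 gives > 166000 nM, which is a limit, so no step to it from compound 1 or compound 2 can be read. The compounds shown leave open how large any of these changes is, and what the change from hydroxy to methyl does.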